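The source may hold more compounds than are shown below. What is called first, only, known or untested is meant among the compounds shown, and "the series" means these compounds.

Measured in a functional assay with Oryctolagus cuniculus as the target (a higher number here means a weaker inhibitor, a lower number a stronger inhibitor), where every value is a limit:

- Compound 1 `COc1ccc(-c2nc(/N=C(\N)[N+]3(C)CCCCC3)sc2-c2ccc(OC)cc2)cc1`: > 1000 nM
- Compound 2 `COc1ccc(-c2nc(/N=C(\N)N3CCOCC3)sc2-c2ccc(OC)cc2)cc1`: < 1000 nM
- Compound 3 `COc1ccc(-c2nc(CN)sc2-c2ccc(OC)cc2)cc1`: > 100 nM

Compound 3 stands on no exact number, only on its limit of > 100 nM.

Compound 4 `COc1ccc(-c2nc(CNC(=O)CSC)sc2-c2ccc(OC)cc2)cc1` comes from it by one change, ((methylsulfanyl)methyl)carbonyl in place of hydrogen on an amine nitrogen, which turns aminomethyl to ((((methylsulfanyl)methyl)carbonyl)amino)methyl.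

The closest measured changes replace the whole group on an aromatic carbon, and they are a step that the limit leaves unreadable from compound 2 to compound 3 and a step that the two limits leave unreadable from compound 1 to compound 3. The remaining change, a number no higher from compound 1 to compound 2 (the limit leaves the size open), lies on a carbon with a double bond to nitrogen. None of these has a readable size, and none adds a group on the amine nitrogen. No direction can therefore be carried over, and this assay offers only a loose expectation. The expected step is a step that the limit leaves unreadable from compound 3 to compound 4. For compound 4 the estimated value is 500 nM, with an expected range of 50 nM to 5000 nM.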

Compound 4, half-maximal inhibitory concentration: < 100 nM
Compound 4: a limit, no number (the forecaster's own chance of this, stated with the estimate: 60%); at least 5.0-fold (0.69 log units) between middle value and limit.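

In this assay, compound 4 gives < 100 nM, which is a limit and not an exact number. Going by these compounds, on the amine nitrogen of compound 3, ((methylsulfanyl)methyl)carbonyl in place of hydrogen gives a number no higher from compound 3 to compound 4 (the limit leaves the size open), so this nitrogen can carry the group with no rise in the number, although the size of the gain remains unknown. Going by these compounds alone, the only step with a readable minimum is an at least 10-fold lower number from compound 1 to compound 4 (1.00 log units; beyond the scatter), but it replaces a whole group on an aromatic carbon and does not isolate the change on the nitrogen.

The step between compound 2 and compound 4 cannot be read, as both values are limits. Also open, on these data alone, is whether the sulfur in the new group matters, for which an acetyl group or a longer carbon chain on the same nitrogen would be the comparison.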